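Urea in place of sulfonamide on the shared core

The source may report more compounds than this note shows. Statements on the series, on what has been measured and on what is new or still open speak of the compounds shown alone.

Measured so far in a functional assay on HL-60 cells (Homo sapiens) for antiproliferative activity, read by MTT assay, with a stated time of 72 h; on this read-out higher numbers stand for weaker inhibition and lower numbers for stronger inhibition:
compound 1 `CN(C(=O)C(C)(C)C)c1ccc2[nH]c(-c3n[nH]c4ccccc34)cc2n1` gives 4990 nM;
compound 2 `CN(C(=O)c1ccc(F)cc1)c1ccc2[nH]c(-c3n[nH]c4ccccc34)cc2n1` gives 1210 nM;
compound 3 `CN(c1ccc2[nH]c(-c3n[nH]c4ccccc34)cc2n1)S(=O)(=O)c1ccccc1` gives 3700 nM.

Compound 3 holds the second-highest number of the three. Its nearest neighbour is compound 1, the step of a 1.3-fold lower number from compound 1 to compound 3 (0.13 log units; within the scatter) lying within the scatter; its furthest is compound 2, with a 3.1-fold higher number from compound 2 to compound 3 (0.49 log units; beyond the scatter) beyond it. Compound 4 `CN(C(=O)Nc1ccccc1)c1ccc2[nH]c(-c3n[nH]c4ccccc34)cc2n1` differs from compound 3 by phenylcarbamoyl in place of phenylsulfonyl on a nitrogen on an aromatic ring. Among the measured compounds shown here, no measured pair carries a phenylcarbamoyl, so only the spread among the three acyl and sulfonyl variants, bounded by a 4.1-fold lower number from compound 1 to compound 2 (0.62 log units; beyond the scatter), bears on the step. A shift within that spread is expected, slightly toward lower numbers: compound 4 is estimated at 2200 nM in this assay, between 700 nM and 7000 nM. The expected step is a 1.7-fold lower number from compound 3 to compound 4 (0.23 log units; within the scatter), within the scatter.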

Compound 4, half-maximal inhibitory concentration: 8.3 nM
Estimate against measurement, compound 4: 270-fold (2.42 log units) above; the measured number lies below the stated range.
By their numbers in this assay, from the lowest: compound 4; then compound 2; then compounds 3 and 1 (each within the scatter of the next).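

At this nitrogen on an aromatic ring, the phenylcarbamoyl group sets compound 4 apart from all three earlier compounds in this assay, with a 450-fold lower number from compound 3 to compound 4 (2.65 log units; beyond the scatter), a 150-fold lower number from compound 2 to compound 4 (2.16 log units; beyond the scatter) and a 600-fold lower number from compound 1 to compound 4 (2.78 log units; beyond the scatter), each large. The earlier changes at this position had shown nothing of this size, so the position tolerates far more variation in activity than they suggested. Nothing available accounts for the gain.

The compounds shown leave open whether the gain depends on the anilino nitrogen or on its phenyl ring. A methoxy or cyclohexylamino group on the carbonyl carbon would help separate the two.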